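Shifting a trifluoromethyl group on a shared core

A few compounds are considered here, and "the series" means these few. Any claim that something is new, unique, unknown or untested is made for them only; others in the source may bear on it.

Compound 1 `Oc1cccc(-c2cc(-c3ccccc3C(F)(F)F)cc(-c3ccccc3O)n2)c1`, compound 2 `Oc1cccc(-c2cc(-c3cccc(C(F)(F)F)c3)cc(-c3ccccc3O)n2)c1` and compound 3 `Oc1cccc(-c2cc(-c3ccccc3C(F)(F)F)cc(-c3cccc(O)c3)n2)c1` were tested in a functional assay on HCT-15 cells (Homo sapiens) for inhibition; on this read-out higher numbers stand for weaker inhibition and lower numbers for stronger inhibition. Compound 1 gives 9010 nM, compound 2 gives 6460 nM and compound 3 gives 8150 nM. Compound 2 differs from compound 1 by 3-(trifluoromethyl)phenyl in place of 2-(trifluoromethyl)phenyl on an aromatic carbon, a change that made a 1.4-fold lower number from compound 1 to compound 2 (0.14 log units; within the scatter). Compound 3 differs from compound 1 in its core by 3-hydroxyphenyl in place of 2-hydroxyphenyl on an aromatic carbon, a change that made a 1.1-fold lower number from compound 1 to compound 3 (0.04 log units; within the scatter). Compound 4 `Oc1cccc(-c2cc(-c3cccc(C(F)(F)F)c3)cc(-c3cccc(O)c3)n2)c1` has not yet been measured; it differs from compound 3 by 3-(trifluoromethyl)phenyl in place of 2-(trifluoromethyl)phenyl on an aromatic carbon. For the measured compounds named here, this is the same kind of change as the one from compound 1 to compound 2, but the surroundings are not identical: in compound 1 the changed position is meta to a 2-hydroxyphenyl group and meta to a 3-hydroxyphenyl group, whereas in compound 3 it is meta to two 3-hydroxyphenyl groups. Because the earlier change made a 1.4-fold lower number from compound 1 to compound 2 (0.14 log units; within the scatter), the step from compound 3 to compound 4 is expected to be of similar size, a 1.4-fold lower number from compound 3 to compound 4 (0.13 log units; within the scatter). Compound 4 is therefore estimated at 6000 nM in this assay, expected to fall between 3000 nM and 12000 nM.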

Compound 4, half-maximal inhibitory concentration: 13600 nM
The estimate for compound 4 lay 2.3-fold (0.36 log units) below the measured number; measured number outside the range, above it.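

In this assay, moving the trifluoromethyl group gives a 1.7-fold higher number from compound 3 to compound 4 (0.22 log units; within the scatter), and moving the hydroxyl group on one phenyl ring gives a 2.1-fold higher number from compound 2 to compound 4 (0.32 log units; beyond the scatter); only the second of these steps stands beyond the usual scatter, and only modestly. Set beside its earlier counterpart, the trifluoromethyl move cannot be told apart between the two cores: the same change on two cores in this assay, a 1.4-fold lower number (0.14 log units; within the scatter) from compound 1 to compound 2 and a 1.7-fold higher number (0.22 log units; within the scatter) from compound 3 to compound 4, 2.3-fold (0.37 log units) apart, within the scatter of two such steps. For the compounds shown here, the same holds for the hydroxyl move, so this series offers no firm sign that the core alters either change, yet with only two cores and such small steps it does not prove that either change carries over intact: the same change on two cores in this assay, a 1.1-fold lower number (0.04 log units; within the scatter) from compound 1 to compound 3 and a 2.1-fold higher number (0.32 log units; beyond the scatter) from compound 2 to compound 4, 2.3-fold (0.37 log units) apart, within the scatter of two such steps.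

The compounds shown vary only the positions of the trifluoromethyl and hydroxyl groups, so it remains open whether these moves would behave alike with other groups in those places, such as a methoxy group or a chlorine atom. Also open, from the compounds shown here alone, is whether a step large enough to stand clear of the scatter would carry over from one core to another.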